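This account rests on a few compounds, and the source may have more. Where it says the series, first, only, none or still open, it means among the compounds named here.

For the measured compounds named here, in a functional assay on the whole organism (Hippocampus) with Rattus norvegicus as the target (on this read-out lower numbers stand for smaller maximal responses and higher numbers for larger maximal responses), compound 3 `COC(=O)C1CC2CNC1C2` gives 103%, the highest of the three numbers measured so far. Compound 1 `COC(=O)C1CC2CC1N(C)C2` gives 39% and compound 2 `COC(=O)[C@@H]1C[C@@H]2C[C@H]1N(C)C2` gives 33% in this assay; the step of a number 64 percentage points higher from compound 1 to compound 3 (beyond the scatter) goes with hydrogen in place of methyl on an amine nitrogen in a ring. Compound 4 `COC(=O)[C@@H]1C[C@H]2CN[C@@H]1C2` differs from compound 3 in the following way: the two compounds have the same atoms and bonds; at least one stereo element is drawn with a configuration in one of them and without one in the other: 3 of 3 stereo elements differ; a stereocentre at a saturated ring carbon is drawn without a configuration in compound 3 and R in compound 4; a stereocentre at a saturated ring carbon is drawn without a configuration in compound 3 and R in compound 4; a stereocentre at a saturated ring carbon is drawn without a configuration in compound 3 and R in compound 4. Going by the values given here, the only measured step of the same kind is a number 6 percentage points lower from compound 1 to compound 2 (within the scatter), and there the fact that one of compounds 1 and 2 is drawn with a defined configuration and the other without, at the place where they differ is all that separates the two. The analyst therefore expects no step beyond the scatter in this assay and estimates a number 6 percentage points lower from compound 3 to compound 4 (within the scatter). For compound 4 the analyst expects a value of about 97% in this assay, within a range from 80% to 115%.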

Compound 4, largest response reached (reported as efficacy), in percent of the reference or control that the assay uses: 120%
Compound 4: the middle estimate sits 23 percentage points below what was measured; the whole stated range lies below it.
By their numbers in this assay, from the lowest: compounds 2 and 1 (each within the scatter of the next); then compound 3; then compound 4.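

In this assay, for the compounds shown here, the step of a number 17 percentage points higher from compound 3 to compound 4 (beyond the scatter) is the first of this kind to lie beyond the scatter, and only this separates the two: the fact that one of compounds 3 and 4 is drawn with a defined configuration and the other without, at the place where they differ. The same kind of step on the methyl-bearing pair stayed within the scatter. Hydrogen in place of methyl on an amine nitrogen in a ring also goes with a number 87 percentage points higher from compound 2 to compound 4 (beyond the scatter) and the size of this change differs between the two cores: the same change on two cores in this assay, a number 64 percentage points higher (beyond the scatter) from compound 1 to compound 3 and a number 87 percentage points higher (beyond the scatter) from compound 2 to compound 4, 23 percentage points apart, beyond the scatter of two such steps.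

The compounds shown leave open how the opposite configuration reads. They also leave open whether an ethyl group on the ring nitrogen, or a carboxylic acid in place of the methyl ester, keeps this response.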